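A chloro group added to compound 2

A few compounds are considered here, and "the series" means these few. Any claim that something is new, unique, unknown or untested is made for them only; others in the source may bear on it.

Measured in a physicochemical assay for solubility, in phosphate buffer, with a stated time of 2 h, at pH 7.4; a lower number here means a less soluble compound, a higher number a more soluble compound:
Compound 1 `COc1ccc(-c2csc(Nc3ccc(Cl)cn3)n2)nc1`: < 10000 nM
Compound 2 `FC(F)(F)c1ccc(-c2csc(Nc3ccc(Cl)cn3)n2)nc1`: < 10000 nM
Compound 3 `CCOc1ccc(-c2csc(Nc3ccc(Cl)cn3)n2)nc1`: < 10000 nM

All three entries are limits of the assay and not numbers, and the whole set rests on (the limit of < 10000 nM in this assay, at which 3 of the 3 values shown sit). In this assay compound 2 stands at < 10000 nM, which is a limit.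

Compound 4 `FC(F)(F)c1ccc(-c2nc(Nc3ccc(Cl)cn3)sc2Cl)nc1` differs from compound 2 in one place, with chloro in place of hydrogen on an aromatic carbon. Among the compounds with values here, none of the measured steps puts a chloro group on the shared core. They comprise a step that the two limits leave unreadable from compound 1 to compound 3 and a step that the two limits leave unreadable from compound 2 to compound 3. The remaining one, a step that the two limits leave unreadable from compound 1 to compound 2, also gives no size to carry over to compound 4, so no change beyond the scatter is expected in this assay, in either direction. Another limit is the most likely report.

The expected change is a step that the limit leaves unreadable from compound 2 to compound 4. For compound 4 the estimated value is 4000 nM, with an expected range from 500 nM to 10000 nM.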

Compound 4, solubility: < 10000 nM
Compound 4: a limit, no number (the forecaster's own chance of this, stated with the estimate: 85%); the middle value lies beyond the limit too.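

Within the data shown here, compound 2 and compound 4 are both limits and not numbers in this assay, and no step between them can be read. The compounds shown leave open how soluble any of them is and whether chloro in place of hydrogen on an aromatic carbon changes that at all, as the whole set rests on one value: the limit of < 10000 nM in this assay, at which 4 of the 4 values shown sit.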